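The source may hold more compounds than are shown below. What is called first, only, known or untested is meant among the compounds shown, and "the series" means these compounds.

Compound 1 `Clc1ccc(-c2cc(-c3cccnc3)nc(-c3ccsc3)c2)o1` is the reference point of this small series. In a functional assay on HCT-15 cells (Homo sapiens) for cytotoxicity, in the presence of a further agent that is not named here (on this read-out lower numbers stand for stronger inhibition and higher numbers for weaker inhibition), compound 1 reaches only the limit of the assay, > 50000 nM, and not a number. That places it at the limit of > 50000 nM in this assay, at which 1 of the 2 values shown sits. Within the data shown here, compound 2 `Clc1ccc(-c2cc(-c3ccoc3)cc(-c3cccs3)n2)cc1` gives 50000 nM in this assay, so compound 1 sits alongside it on the numbers in hand, with no measured step between the two. Compound 3 `Clc1ccc(-c2cc(-c3ccsc3)nc(-c3ccccc3Cl)c2)o1` differs from compound 1 by 2-chlorophenyl in place of pyridin-3-yl on an aromatic carbon. Among the measured compounds shown here, with no measured step to draw on, the expected step of a number no higher from compound 1 to compound 3 (the limit leaves the size open) is none beyond the scatter, and a limit again seems likely. Compound 3 is estimated at 50000 nM, within 20000 nM to 100000 nM.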

Compound 3, half-maximal inhibitory concentration: 4570 nM
Compound 3: middle estimate off by 11-fold (1.04 log units), on the high side; measured number below the stated range.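

In this assay, 2-chlorophenyl in place of pyridin-3-yl on the aromatic carbon next to the ring nitrogen gives an at least 10-fold lower number from compound 1 to compound 3 (1.03 log units; beyond the scatter). Among these compounds, this position therefore responds to the group it carries, which the earlier compounds could not show. The step is open on one side, as compound 1 stands at a limit: the limit of > 50000 nM in this assay, at which 1 of the 3 values shown sits.

The compounds shown do not separate the chlorine from the loss of the ring nitrogen of pyridin-3-yl. Going by these compounds, how plain phenyl, an amine or a carboxylic acid would read out at this position also remains open.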